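Carbamate ester appendage trimming on a shared core

A few compounds are considered here, and "the series" means these few. Any claim that something is new, unique, unknown or untested is made for them only; others in the source may bear on it.

For the measured compounds named here, compound 1 `CC(OC(=O)C(C)C)OC(=O)N1CCN(C(=O)c2nc(Nc3cc(C4CC4)[nH]n3)c3cc(Cl)ccc3n2)C[C@H]1C` stands highest of the two numbers measured so far in an assay for inhibition of serine/threonine-protein kinase PAK 4 (Homo sapiens), read by FRET and Z'-LYTE, with a stated time of 60 min, tested at 50 uM, in the presence of a further agent that is not named here (on this read-out lower numbers stand for a weaker effect and higher numbers for a stronger effect at the one concentration tested), where compound 1 gives 71.7%. Its nearest neighbour is compound 2 `CC(OC(=O)N1CCN(C(=O)c2nc(Nc3cc(C4CC4)[nH]n3)c3cc(Cl)ccc3n2)C[C@H]1C)OC(=O)C(C)(C)C`, and in this assay compound 2 gives 65.3%. Going by the values given here, the only measured step is a number 6.4 percentage points lower from compound 1 to compound 2 (within the scatter), a change on the ester appendage that stayed within the scatter.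

Compound 3 `CC(C)C(=O)OCOC(=O)N1CCN(C(=O)c2nc(Nc3cc(C4CC4)[nH]n3)c3cc(Cl)ccc3n2)C[C@H]1C` has not yet been measured in this assay. It differs from compound 1 by hydrogen in place of methyl on a saturated chain carbon bound to two oxygens next to a carbonyl group. The step of a number 6.4 percentage points lower from compound 1 to compound 2 (within the scatter) is the only one that bears on this change, since it also alters a small alkyl group on the same appendage, and it produced no movement beyond the scatter. Among the compounds with values here, on that basis the removal of a methyl from compound 1 to give compound 3 is expected to produce no step in this assay beyond the usual scatter. For compound 3 the estimated result in this assay is 70%, with a range from 56% to 82%. This corresponds to an expected step of a number 1.7 percentage points lower from compound 1 to compound 3 (within the scatter).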

Compound 3, a percentage reported as inhibition, at one concentration (the size of the read-out at that concentration, not a potency): 86.9%
Compound 3: the middle estimate sits 16.9 percentage points below what was measured; the measured number lies above the stated range.
By their numbers in this assay, from the lowest: compounds 2 and 1 (each within the scatter of the next); then compound 3.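

In this assay, for the compounds shown here, hydrogen in place of methyl on a saturated chain carbon bound to two oxygens next to a carbonyl group gives a number 15.2 percentage points higher from compound 1 to compound 3 (beyond the scatter), so this carbon is the first place where a change moves the read-out beyond the scatter, whereas the methyl added on the saturated chain carbon bound to a carbonyl carbon and two saturated chain carbons gave only a number 6.4 percentage points lower from compound 1 to compound 2 (within the scatter). The exchange of 1-(((tert-butyl)carbonyl)oxy)ethyl for ((isopropylcarbonyl)oxy)methyl on an oxygen next to a carbonyl group gives a number 21.6 percentage points higher from compound 2 to compound 3 (beyond the scatter), which places compound 3 beyond the scatter of both earlier compounds. Nothing available accounts for the size of these steps.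

The compounds shown leave open how the read-out responds to an ethyl group in place of the methyl or hydrogen on the saturated chain carbon bound to two oxygens, and so whether the effect tracks the size of that substituent or only the presence of hydrogen. They also leave open whether a ((tert-butylcarbonyl)oxy)methyl appendage matches compound 3, and each number remains a read-out at one concentration, not a potency.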